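The source may hold more compounds than are shown below. What is called first, only, known or untested is meant among the compounds shown, and "the series" means these compounds.

Measured compounds:
- compound 2 `CS(=O)(=O)c1ccc2nc(-c3ccc(-c4ccccc4)cc3)[nH]c2c1`: 20 nM
- compound 1 `CN(C)S(=O)(=O)c1ccc2nc(-c3ccc(-c4ccccc4F)cc3)[nH]c2c1`: 528 nM

In an assay on isolated protein for inhibition of acyl-CoA desaturase 1 (Rattus norvegicus) (on this read-out higher numbers stand for weaker inhibition and lower numbers for stronger inhibition), compound 2 gives 20 nM, the lowest of the two numbers recorded. The nearest number belongs to compound 1, which in this assay gives 528 nM; the gap between the two lies beyond the scatter, and since compound 1 and compound 2 differ in more than one place, nothing further is drawn from that pair.

Compound 3 `Cc1cccc(-c2ccc(-c3nc4ccc(S(C)(=O)=O)cc4[nH]3)cc2)c1` is not yet measured. It differs from compound 2 by methyl in place of hydrogen on an aromatic carbon; cut one bond further out, the change reads phenyl to 3-methylphenyl. Going by the values given here, no step between measured compounds covers this change, so the expectation rests on compound 2 alone. A methyl added on this aromatic carbon is expected to move the number little, with no step beyond the scatter in either direction.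

Compound 3 is therefore estimated at 30 nM in this assay, with a range of 8 nM to 110 nM, corresponding to an expected step of a 1.5-fold higher number from compound 2 to compound 3 (0.18 log units; within the scatter).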

Compound 3, half-maximal inhibitory concentration: 319 nM
Compound 3: middle estimate off by 11-fold (1.03 log units), on the low side; the measured number lies above the stated range.
By their numbers in this assay, from the lowest: compound 2; then compounds 3 and 1 (each within the scatter of the next).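

In this assay, going by these compounds alone, the change from phenyl to 3-methylphenyl gives a 16-fold higher number from compound 2 to compound 3 (1.20 log units; beyond the scatter) and is the first step that can be read at a single place. This large step, beyond the scatter, shows that the number at this aromatic carbon, meta to a large group, is sensitive to the addition of a methyl in place of hydrogen. No measurement available here accounts for the step.

From the compounds shown here alone, it remains open whether the higher number is specific to methyl or would also follow from other groups on the same carbon, such as methoxy, chlorine or an amine. Also open, going by these compounds, is whether a methyl on the other carbons of this ring would give a step of similar size.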